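The source may hold more compounds than are shown below. What is called first, only, known or untested is meant among the compounds shown, and "the series" means these compounds.

Three compounds have been measured in a functional assay on A549 cells (Homo sapiens) for cytotoxicity, read by sulforhodamine B assay, with a stated time of 48 h; a higher number here means a weaker inhibitor, a lower number a stronger inhibitor:
Compound 1, `COc1ccc(-c2cc(C(=O)/C=C/c3cc(OC)c(OC)c(OC)c3)ccc2N)cc1OC`, gives 4620 nM.
Compound 2, `COc1ccc(-c2cc(C(=O)/C=C/c3cccc(OC)c3OC)ccc2N)cc1OC`, gives 6540 nM.
Compound 3, `COc1cc(/C=C/C(=O)c2ccc(N)c(-c3ccc(F)cc3)c2)cc(OC)c1OC`, gives 6070 nM.

Compound 1 and compound 3 share one core and differ in a single place: 4-fluorophenyl in place of 3,4-dimethoxyphenyl on an aromatic carbon. That exchange produced a 1.3-fold higher number from compound 1 to compound 3 (0.12 log units; within the scatter), so the two numbers cannot be told apart with any confidence. Compound 2 is built on a different core; the difference between the core of compound 1 and the core of compound 2 is not broken down here. The number for compound 2 lies close to those of compound 1 and compound 3, and none of the three can be called stronger or weaker than the others.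

Compound 4, `COc1cccc(/C=C/C(=O)c2ccc(N)c(-c3ccc(F)cc3)c2)c1OC`, has not yet been measured. It arises from compound 2 by the same exchange that leads from compound 1 to compound 3: 4-fluorophenyl in place of 3,4-dimethoxyphenyl on an aromatic carbon. The surroundings of the exchanged group read the same in both pairs, so this is the same change, seen once so far among the measured compounds.

In this assay compound 4 is expected to give 7500 nM, with a plausible range from 3500 nM to 16000 nM. Among the measured compounds shown here, the expected step is a 1.1-fold higher number from compound 2 to compound 4 (0.06 log units; within the scatter), because the only measured example of this change was a 1.3-fold higher number from compound 1 to compound 3 (0.12 log units; within the scatter). With a single precedent, and that one inside the scatter, the forecast for compound 4 is essentially that its number will sit near the number of compound 2.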

Compound 4, half-maximal inhibitory concentration: 13300 nM
For compound 4 the middle estimate is 1.8-fold (0.25 log units) below the measured one; the range from low to high includes it.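

In this assay, putting 4-fluorophenyl in place of 3,4-dimethoxyphenyl gives a 2.0-fold higher number from compound 2 to compound 4 (0.31 log units; beyond the scatter), a modest step that lies only just outside the usual noise of the measurement. Set side by side, the two examples of this change point the same way and cannot be told apart in size, so on these two cores the exchange carries over as a small loss or as no real change at all: the same change on two cores in this assay, a 1.3-fold higher number (0.12 log units; within the scatter) from compound 1 to compound 3 and a 2.0-fold higher number (0.31 log units; beyond the scatter) from compound 2 to compound 4, 1.5-fold (0.19 log units) apart, within the scatter of two such steps This does not establish a rule for the series, since it rests on only two pairs, one of which lies within the scatter, and it says nothing about why the numbers move or how the change would behave on any other core.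

The exchange removes two methoxy groups and adds a fluorine in a single move, so the compounds shown leave open what each of these alterations contributes, which an unsubstituted phenyl or a phenyl carrying a single methoxy group could help to separate. Every compound shown also keeps the same amino group on the ring that carries the exchanged group, so it remains open how an acetamide or a hydroxyl group in its place would compare.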